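The source may hold more compounds than are shown below. What is called first, only, known or untested is meant among the compounds shown, and "the series" means these compounds.

In an ADME assay on KB cells (Homo sapiens) for cytotoxicity, read by MTT assay, with a stated time of 72 h (a lower number here means that less compound is tolerated, a higher number that more compound is tolerated), compound 1 `Clc1ccc(Nc2nc(-c3cccnn3)cs2)nc1` gives 10300 nM. Compound 2 `Clc1ccc(Nc2nc(-c3cnccn3)cs2)nc1` offers no such anchor: its entry reads "not determined" (no result reported), so compound 2 has no single number and cannot be ranked against compound 1. Going by the values given here, no step between two measured compounds is available either, which leaves the size of any structural effect unknown.

Compound 3 `Clc1ccc(Nc2nc(-n3cccn3)cs2)nc1` departs from compound 2 at one place on the shared core: 1H-pyrazol-1-yl in place of pyrazin-2-yl on an aromatic carbon. A five-membered aromatic ring thus stands where a six-membered aromatic ring stood, and the entering group is still attached on an aromatic carbon. Since compound 2 provides no value, the expectation for compound 3 can lean only on compound 1 at 10300 nM. On that thin basis, no step beyond the usual scatter is expected in this assay, and no direction is favoured, although the uncertainty is wide. For compound 3 the estimated value is 11000 nM, with an expected range from 3500 nM to 35000 nM.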

Compound 3, half-maximal cytotoxic concentration: 20200 nM
The estimate for compound 3 lay 1.8-fold (0.26 log units) below the measured number; low and high end bracket the measured number.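

In this assay, going by these compounds alone, the single change on the shared core gives a 2.0-fold higher number from compound 1 to compound 3 (0.29 log units; within the scatter) and so provides the first step that can be read. At this place, next to the ring nitrogen of the shared core, a five-membered aromatic ring therefore stands where the group of compound 1 stood, with no step beyond the scatter in this read-out, while the step from compound 2 to compound 3 cannot be read, as compound 2 has no number. Nothing on hand offers a measured reason for the two numbers or for how close they stand.

The compounds shown leave open whether a group of another kind at this place, such as an amine, a carboxylic acid or a longer chain, would give a step beyond the scatter. They also leave open whether the result for this single pair would hold on a core that carries something other than the groups shown here.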